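A few compounds are considered here, and "the series" means these few. Any claim that something is new, unique, unknown or untested is made for them only; others in the source may bear on it.

Three compounds sharing one core were tested in a functional assay on HeLa cells (Homo sapiens) for cytotoxicity, read by MTT assay, with a stated time of 48 h; on this read-out lower numbers stand for stronger inhibition and higher numbers for weaker inhibition. Compound 1 `O=c1ccoc2cc(OCc3cn(Cc4cccc(Br)c4)nn3)ccc12` gives only a limit in this assay, > 100000 nM. Compound 2 `O=c1ccoc2cc(OCc3cn(Cc4ccc(Cl)cc4Cl)nn3)ccc12` gives 80600 nM, and compound 3 `CC(C)(C)c1ccc(Cn2cc(COc3ccc4c(=O)ccoc4c3)nn2)cc1` gives 17600 nM, the lowest of the two numbers. Among the compounds with values here, the only measured step, an at least 1.2-fold lower number from compound 1 to compound 2 (0.09 log units; that floor lies within the scatter), starts from a limit of > 100000 nM in this assay, at which 1 of the 3 values shown sits, and is therefore just a floor. Compound 4 `O=c1ccoc2cc(OCc3cn(Cc4ccc(Cl)cc4)nn3)ccc12` differs from compound 3 by chloro in place of tert-butyl on an aromatic carbon. Within the data shown here, no measured step swaps these two groups, and compound 2 and compound 3 differ at more than one place, so guidance is thin. A step back toward the number of compound 2 is expected, a 2.8-fold higher number from compound 3 to compound 4 (0.45 log units; beyond the scatter). Compound 4 is therefore estimated at 50000 nM, within 20000 nM to 150000 nM.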

Compound 4, half-maximal inhibitory concentration: 37600 nM
Beside the measured number, compound 4's estimate is 1.3-fold (0.12 log units) above it, within the range that was stated.
By their numbers in this assay, from the lowest: compound 3; then compound 4; then compound 2. At a limit, above all of these: compound 1.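

Within the data shown here, replacing tert-butyl with chloro on this aromatic carbon gives the first single change here that can be read in full: a 2.1-fold higher number from compound 3 to compound 4 (0.33 log units; beyond the scatter) marks a real shift beyond the scatter. Hydrogen in place of one chloro also counts, since a 2.1-fold lower number from compound 2 to compound 4 (0.33 log units; beyond the scatter) shows that the extra chloro of compound 2 goes with a higher number. The step of an at least 2.6-fold lower number from compound 1 to compound 4 (0.42 log units; beyond the scatter) starts from a limit and is only a floor: the limit of > 100000 nM in this assay, at which 1 of the 4 values shown sits.

On these data alone, how an amine, a carboxylic acid or a methoxy group on this aromatic carbon would compare remains open.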